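This account rests on a few compounds, and the source may have more. Where it says the series, first, only, none or still open, it means among the compounds named here.

Of the compounds shown here, three on one shared core have been measured so far in an assay on HEK293 cells for inhibition of transient receptor potential cation channel subfamily M member 8 (Homo sapiens), read by FLIPR, with stated times of 5 min and 3 min; a higher number here means a weaker inhibitor, a lower number a stronger inhibitor. Compound 1 `CCn1nnc(-c2sc(-c3cccc(C)c3)nc2O)n1` gives 369 nM. Compound 2 `CCn1nnc(-c2sc(-c3cccc(NC)c3)nc2O)n1` gives 1020 nM in this assay. Compound 3 `CCn1nnc(-c2sc(-c3cccc(O)c3)nc2O)n1` gives 239 nM in this assay, the lowest of the three numbers, though the step of a 1.5-fold lower number from compound 1 to compound 3 (0.19 log units; within the scatter) is within the scatter, so those two cannot be ordered, while the step of a 4.3-fold lower number from compound 2 to compound 3 (0.63 log units; beyond the scatter) is beyond it.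

Compound 4 `CCn1nnc(-c2sc(-c3cccc(N(C)C)c3)nc2O)n1` is not yet measured. Its difference from compound 3: dimethylamino in place of hydroxy on an aromatic carbon. For the measured compounds named here, two measured steps bear on this. The step of a 2.8-fold higher number from compound 1 to compound 2 (0.44 log units; beyond the scatter) and the step of a 4.3-fold lower number from compound 2 to compound 3 (0.63 log units; beyond the scatter) both place methylamino at the higher end of the numbers seen, and the dimethylamino group entering in compound 4 is the closest relative of methylamino among the groups measured, with the hydrogen-bond donor of the hydroxy group in compound 3 also given up. Going by the values given here, the step to compound 4 in this assay is therefore expected to be upward by a modest to clear amount rather than within the scatter, with the wide range reflecting that no dimethylamino analogue has been measured.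

Compound 4 is estimated at 900 nM in this assay, within 350 nM to 2500 nM. The expected step is a 3.8-fold higher number from compound 3 to compound 4 (0.58 log units; beyond the scatter).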

Compound 4, half-maximal inhibitory concentration: 4770 nM
Compound 4: middle estimate off by 5.3-fold (0.72 log units), on the low side, and the stated range ends below it.
By their numbers in this assay, from the lowest: compounds 3 and 1 (each within the scatter of the next); then compound 2; then compound 4.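

On the aromatic carbon meta to a large group, the dimethylamino group costs far more in this assay than the methylamino result of compound 2 suggested, with a 20-fold higher number from compound 3 to compound 4 (1.30 log units; beyond the scatter) against the hydroxy group and a 13-fold higher number from compound 1 to compound 4 (1.11 log units; beyond the scatter) against the methyl group. Adding one methyl on the nitrogen is enough to give a 4.7-fold higher number from compound 2 to compound 4 (0.67 log units; beyond the scatter), so methylamino and dimethylamino, close relatives by name, are clearly separate at this position. The dimethylamino group, with 3 heavy atoms, gives the highest number of the four compounds, and every step to compound 4 lies beyond the scatter.

Whether the rise belongs to the nitrogen or to the larger group as such stays open: an isopropyl or a methoxy group on this carbon, and an unsubstituted amine, do not appear among the compounds shown. Nothing among the data shown offers an explanation for the rise.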